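The source may report more compounds than this note shows. Statements on the series, on what has been measured and on what is new or still open speak of the compounds shown alone.

Measured compounds in a functional assay on M21 cells (Homo sapiens) for antiproliferative activity, read by sulforhodamine B assay, with a stated time of 48 h; on this read-out higher numbers stand for weaker inhibition and lower numbers for stronger inhibition:

Compound 1 `CC(C)c1ccccc1OS(=O)(=O)c1ccc(NC(=O)CCl)cc1` gives 3900 nM.
Compound 2 `O=C(CCl)Nc1ccc(S(=O)(=O)Oc2ccccc2I)cc1` gives 3900 nM.
Compound 3 `CCCNC(=O)Nc1ccc(S(=O)(=O)Oc2ccccc2C(C)C)cc1` gives 5100 nM.

Compound 4 `CCCNC(=O)Nc1ccc(S(=O)(=O)Oc2ccccc2I)cc1` has not yet been measured. It arises from compound 3 by iodo in place of isopropyl on an aromatic carbon. The same change is seen once among the measured compounds, in iodo in place of isopropyl on an aromatic carbon, where the result was no change at the digits printed from compound 1 to compound 2 (within the scatter). The cores of compound 1 and compound 3 differ by propylamino in place of chloromethyl on a carbonyl carbon, a change that produced a 1.3-fold higher number from compound 1 to compound 3 (0.12 log units; within the scatter). The place description for the change in compound 4 matches that for compound 2 word for word, so it is the same change on a differently decorated core.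

Because no change at the digits printed from compound 1 to compound 2 (within the scatter) shows no shift, the step from compound 3 to compound 4 is expected to be similarly flat, estimated as a 1.0-fold lower number from compound 3 to compound 4 (0.01 log units; within the scatter). Compound 4 is therefore estimated at 5000 nM, with a range from 2500 nM to 10000 nM.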

Compound 4, half-maximal inhibitory concentration: 5400 nM
Beside the measured number, compound 4's estimate is 1.1-fold (0.03 log units) below it; low and high end bracket the measured number.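

In this assay, iodo in place of isopropyl on an aromatic carbon gives a 1.1-fold higher number from compound 3 to compound 4 (0.02 log units; within the scatter), and this step matches its earlier counterpart on the other core: the same change on two cores in this assay, no change at the digits printed (within the scatter) from compound 1 to compound 2 and a 1.1-fold higher number (0.02 log units; within the scatter) from compound 3 to compound 4, 1.1-fold (0.02 log units) apart, within the scatter of two such steps

Propylamino in place of chloromethyl on a carbonyl carbon gives a 1.4-fold higher number from compound 2 to compound 4 (0.14 log units; within the scatter), and it too matches its earlier counterpart: the same change on two cores in this assay, a 1.3-fold higher number (0.12 log units; within the scatter) from compound 1 to compound 3 and a 1.4-fold higher number (0.14 log units; within the scatter) from compound 2 to compound 4, 1.1-fold (0.02 log units) apart, within the scatter of two such steps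

So both changes stay flat on both cores, but four compounds cannot show how well a change that truly moves the number would carry over, or whether these flat steps would hold on other cores.

Still open, on these data alone, is what a methoxy group or a longer alkyl chain would do on that aromatic carbon. Also open, as far as these compounds go, is whether a simple amine or a carboxylic acid on the carbonyl carbon would shift the number.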